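The source may hold more compounds than are shown below. What is called first, only, known or untested is meant among the compounds shown, and "the series" means these compounds.

Measured so far:
Compound 1 `CC(=O)n1cc(/C=C(/C(=O)O)c2ccc(OCc3ccccc3)cc2)c2cc(OCc3ccccc3)ccc21` gives 43000 nM in a functional assay on KB cells (Homo sapiens) for cytotoxicity, read by MTT assay, with a stated time of 72 h; a higher number here means a weaker inhibitor, a lower number a stronger inhibitor.
Compound 2 `COc1ccc(Cn2cc(/C=C(/C(=O)O)c3ccccc3)c3cc(OCc4ccccc4)ccc32)cc1` gives 97000 nM in this assay.
Compound 3 `COc1ccccc1/C(=C\c1cn(C(C)=O)c2ccc(OCc3ccccc3)cc12)C(=O)O` is reported in this assay only as a limit, > 100000 nM.

Compound 3 therefore stands at the weak end of the numbers shown: the limit of > 100000 nM in this assay, at which 1 of the 3 values shown sits. On these data alone, its entry is a limit of the measurement and not a number, so how weak compound 3 really is remains open. Compound 4 `COc1ccc(/C(=C\c2cn(C(C)=O)c3ccc(OCc4ccccc4)cc23)C(=O)O)cc1OC` differs from compound 3 in a single place: 3,4-dimethoxyphenyl in place of 2-methoxyphenyl on a double-bonded chain carbon bound to a carbonyl carbon and a double-bonded chain carbon. Going by the values given here, no pair of measured compounds differs in only this one place, so there is no measured step to set the size of this change. Compounds 1 and 2 differ from compound 4 in more than one place, and their values show only the band in which the measured compounds sit, all of them weak inhibitors in this assay. On this evidence the change from compound 3 to compound 4 is expected to bring no step beyond the usual scatter, which the estimated step of an at least 1.1-fold lower number from compound 3 to compound 4 (0.04 log units; that floor lies within the scatter) expresses. Compound 4 is accordingly expected to give about 90000 nM in this assay, with a plausible range from 30000 nM to 300000 nM, and a fair chance that only a limit is reported again.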

Compound 4, half-maximal inhibitory concentration: 96700 nM
Beside the measured number, compound 4's estimate is 1.1-fold (0.03 log units) below it; measured number inside the range.
By their numbers in this assay, from the lowest: compound 1; then compounds 4 and 2 (each within the scatter of the next). At a limit, above all of these: compound 3.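

Replacing 2-methoxyphenyl with 3,4-dimethoxyphenyl on a double-bonded chain carbon bound to a carbonyl carbon and a double-bonded chain carbon now has its first measured step in this assay: an at least 1.0-fold lower number from compound 3 to compound 4 (0.01 log units; that floor lies within the scatter). This step is only a floor, but the larger group gives a measured number at a place where the earlier entry was only a limit, and that number remains in the weak band of the set. Compound 3 remains a limit and not a number, so the true size of the step stays open: the limit of > 100000 nM in this assay, at which 1 of the 4 values shown sits.

The compounds shown leave open whether an amine, a hydroxyl group or a fluorine atom on this phenyl ring would move the number out of the weak band. They also leave open whether an amide in place of the carboxylic acid, with the phenyl ring and the rest of the core kept the same, would change the picture.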